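Moving an ethoxy group onto a second, unsaturated core

This account rests on a few compounds, and the source may have more. Where it says the series, first, only, none or still open, it means among the compounds named here.

Compounds 1 and 2 share a saturated bicyclic core; compound 3 and compound 4 carry a ring double bond instead, and the difference between the two cores is not broken down here. Compound 1 `CO[C@H]1CC[C@H]2CCN(C)[C@H]2C1` gives only a limit in an assay on HEK293 cells for displacement of a labelled ligand from Neuronal acetylcholine receptor; alpha3/beta4 (Rattus norvegicus), with a stated time of 4 h (on this read-out higher numbers stand for weaker inhibition and lower numbers for stronger inhibition), namely > 300000 nM. Compound 2 `CCO[C@H]1CC[C@H]2CCN(C)[C@H]2C1` gives 300000 nM in this assay. The change between them, (methyl in place of hydrogen on a saturated chain carbon bound to an oxygen on a saturated carbon), is reported as a number no higher from compound 1 to compound 2 (the limit leaves the size open), and its size cannot be read because of the limit of > 300000 nM in this assay, at which 1 of the 3 values shown sits.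

Compound 3 `CO[C@H]1CC=C2CCN(C)[C@H]2C1` gives 100000 nM in this assay, the lowest of the two numbers measured. Compound 4 `CCO[C@H]1CC=C2CCN(C)[C@H]2C1` differs from compound 3 by methyl in place of hydrogen on a saturated chain carbon bound to an oxygen on a saturated carbon, the same change as from compound 1 to compound 2, at the same place.

With only a limit-bound step to go on, compound 4 is expected to stay close to compound 3, so the step of a 1.5-fold higher number from compound 3 to compound 4 (0.18 log units; within the scatter) is estimated to be small. The estimate for compound 4 in this assay is 150000 nM, with a range from 50000 nM to 400000 nM, resting on compound 3 at 100000 nM.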

Compound 4, inhibition constant: > 300000 nM
Compound 4 ended at the assay's limit; the forecaster's own chance of this, stated with the estimate: 25%; middle value at least 2.0-fold (0.30 log units) away from the limit.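

In this assay, the change from methoxy to ethoxy on the core with the ring double bond weakens binding, giving an at least 3.0-fold higher number from compound 3 to compound 4 (0.47 log units; beyond the scatter). The result on this core therefore cannot be taken over from the saturated core, where the same change gives a different outcome: the same change on two cores in this assay, a number no higher (the limit leaves the size open) from compound 1 to compound 2 and an at least 3.0-fold higher number (0.47 log units; beyond the scatter) from compound 3 to compound 4, at least 3.0-fold (0.47 log units) apart, beyond the scatter of two such steps. The true size of neither step is known, and this pair of cores gives no rule for any other core, since the exact numbers are hidden by the assay's ceiling: the limit of > 300000 nM in this assay, at which 2 of the 4 values shown sit.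

The compounds shown leave open how a longer chain such as propyl, or a hydroxyl group or an amine at the same place, would behave on either core. They also leave open whether any such group would bring the numbers on both cores clear of the limit, so that the two steps could be compared by size.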